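Dimethylamino for methyl on the pendant aryl ring

This account rests on a few compounds, and the source may have more. Where it says the series, first, only, none or still open, it means among the compounds named here.

Measured so far:
compound 1, `Cc1ccc2c(=O)[nH]c(-c3ccccc3C)nc2c1`: > 50000 nM
compound 2, `Cc1ccc2nc(-c3ccccc3C)[nH]c(=O)c2c1`: 4580 nM

In a functional assay on HeLa cells (Homo sapiens) for cytotoxicity, read by MTT assay, with a stated time of 2 days (on this read-out lower numbers stand for stronger inhibition and higher numbers for weaker inhibition), compound 1 gives only a limit, > 50000 nM, and not a number. Compound 1 therefore sits at the limit of > 50000 nM in this assay, at which 1 of the 2 values shown sits. In this assay compound 2 gives 4580 nM. Among the measured compounds shown here, no step between the two measured compounds is defined, and their two values show only that compound 2 has a measured number where compound 1 has a limit.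

Compound 3, `Cc1ccc2c(=O)[nH]c(-c3ccccc3N(C)C)nc2c1`, is not yet measured in this assay. It differs from compound 1 in one place: dimethylamino in place of methyl on an aromatic carbon. For the measured compounds named here, no measured step for this kind of change exists in this assay, so no direction can be read from the data; the expectation is a step not clearly beyond the scatter, an at least 1.2-fold lower number from compound 1 to compound 3 (0.09 log units; that floor lies within the scatter). Compound 3 is accordingly expected to give about 40000 nM in this assay, with a range from 8000 nM to 200000 nM, and a real chance that again only a limit is reported.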

Compound 3, half-maximal inhibitory concentration: 43800 nM
Estimate against measurement, compound 3: 1.1-fold (0.04 log units) below; the measured number falls inside the stated range.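

Compound 1 remains a limit and not a number in this assay: the limit of > 50000 nM in this assay, at which 1 of the 3 values shown sits. Among the compounds shown here, with dimethylamino in place of methyl on an aromatic carbon, ortho to a large group, compound 3 gives 43800 nM, the first actual number for a change at this position. For the compounds shown here, the change amounts to an at least 1.1-fold lower number from compound 1 to compound 3 (0.05 log units; that floor lies within the scatter), so the larger group at this position yields a measurable value but no step clearly beyond the scatter.

On these data alone, whether a primary amine, a methoxy group or a carboxylic acid at this place would move the number further stays open. Also open, as far as these compounds go, is whether dimethylamino would act the same way on the core of compound 2, which gives 4580 nM.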